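Cytotoxicity of a Thiazolyl Aminothiazole Series in Muscle Cells

The compounds below may be only part of what the source reports. "The series", "measured", "known", "first", "only" and "open" are said of these compounds alone.

Measured so far:
compound 1, `CC(=O)c1cccc(Nc2nc(-c3sc(NC(=O)C(F)(F)F)nc3C)cs2)c1`, 30100 nM;
compound 2, `CC(=O)c1cccc(Nc2nc(-c3sc(NC(=O)OC(C)(C)C)nc3C)cs2)c1`, 101000 nM;
compound 3, `CC(=O)Nc1nc(C)c(-c2csc(Nc3ccccc3)n2)s1`, "not determined" (no result reported).

The three compounds share a core and differ in the group on the amide carbonyl and in the substitution of the aniline ring. In an ADME assay on RD cells (Homo sapiens) for cytotoxicity, read by microscopy (on this read-out higher numbers stand for lower toxicity in this test and lower numbers for higher toxicity in this test), compound 1 gives 30100 nM, and compound 2 gives 101000 nM. Going by the values given here, the single step between them, a 3.4-fold higher number from compound 1 to compound 2 (0.53 log units; beyond the scatter), concerns only the carbonyl group. Compound 3 stands apart: in this assay compound 3 gives "not determined" (no result reported), so there is no number to anchor it.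

Compound 4, `CC(=O)Nc1nc(C)c(-c2csc(Nc3cccc(C(C)=O)c3)n2)s1`, is the next compound to be tested. It differs from compound 3 by acetyl in place of hydrogen on an aromatic carbon. Among the compounds with values here, no measured step concerns this change, and the one measured step, a 3.4-fold higher number from compound 1 to compound 2 (0.53 log units; beyond the scatter), bears on a different part of the molecule. Within the data shown here, the only guide is that compounds 1 and 2, which both carry the acetyl group that enters here, show the two values above, so the expectation for compound 4 in this assay rests on that level rather than on any step. Compound 4 is therefore expected to give about 50000 nM, within a range of 15000 nM to 160000 nM.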

Compound 4, half-maximal cytotoxic concentration: 9730 nM
Beside the measured number, compound 4's estimate is 5.1-fold (0.71 log units) above it; the whole stated range lies above it.
By their numbers in this assay, from the lowest: compound 4; then compound 1; then compound 2.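

The step from compound 3 to compound 4 cannot be read, since compound 3 has no number in this assay and the acetyl on the aromatic carbon therefore has no measured effect of its own. With that acetyl present in all three measured compounds, the result shows instead that the group on the carbonyl carbon still moves the number: methyl in place of tert-butoxy gives a 10-fold lower number from compound 2 to compound 4 (1.02 log units; beyond the scatter), and methyl in place of trifluoromethyl gives a 3.1-fold lower number from compound 1 to compound 4 (0.49 log units; beyond the scatter), which puts methyl at the low end of these three, the end of higher toxicity in this test. Nothing among the data shown accounts for this order.

The compounds shown leave open what the acetyl contributes on the six-membered aromatic ring of carbon only, and whether a nitrile, a carboxylic acid or an amine at that place would give a higher or a lower number. They also leave open where a longer chain on the carbonyl carbon, such as ethyl or propyl, would fall relative to methyl and tert-butoxy.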